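A few compounds are considered here, and "the series" means these few. Any claim that something is new, unique, unknown or untested is made for them only; others in the source may bear on it.

Measured so far:
compound 1, `C1=NC(CC2CCc3ccccc3O2)CN1`: in an assay on isolated protein for binding affinity to Adrenergic receptor alpha-1 (Rattus norvegicus), read by radioligand binding, in the presence of a further agent that is not named here (on this read-out lower numbers stand for stronger inhibition and higher numbers for weaker inhibition), compound 1 gives 316 nM
compound 2, `C1=NC[C@@H](C2CC23Cc2ccccc2C3)N1`: in this assay compound 2 gives 6310 nM

Compound 2 stands at the higher of the two numbers; the gap to compound 1 is beyond the scatter, so compound 2 is the weaker of the two on this read-out. Among the compounds with values here, no step between measured compounds of one single change is available, and compound 1 carries a different core with no stereocentre specified, so it gives no direct guide.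

Compound 3, `C1=NC[C@H](C2CC23Cc2ccccc2C3)N1`, differs from compound 2 only in configuration: the two compounds have the same atoms and bonds; at least one stereo element is drawn with a configuration in one of them and without one in the other: 1 of 2 stereo elements differ; a stereocentre at a saturated ring carbon is drawn R in compound 2 and S in compound 3. Inversion of a single stereocentre on an otherwise identical structure can leave the number unchanged or move it well beyond the scatter in either direction; with compound 2 already at the high end, the room for a further rise is smaller than for a fall. The step from compound 2 to compound 3 is expected to be a 4.2-fold lower number from compound 2 to compound 3 (0.62 log units; beyond the scatter) in this assay, towards a lower number. Compound 3 is estimated at 1500 nM, within 250 nM to 8000 nM.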

Compound 3, inhibition constant: 126 nM
The estimate for compound 3 lay 12-fold (1.08 log units) above the measured number; measured number below the stated range.
By their numbers in this assay, from the lowest: compound 3; then compound 1; then compound 2.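

This stereocentre at a saturated ring carbon is a sensitive position: in this assay, going from the R to the S drawing gives a 50-fold lower number from compound 2 to compound 3 (1.70 log units; beyond the scatter), with no atom or bond changed. Within the data shown here, the earlier compounds offered no pair differing in one place, so this is the first isolated change, and it shows that configuration at this one carbon is enough to move the number well beyond the scatter. One caution applies to reading the step as a clean comparison of two configurations: the fact that one of compounds 2 and 3 is drawn with a defined configuration and the other without, at the place where they differ

The compounds shown leave open whether the preference for the S drawing persists when a hydroxyl group or a methyl group is added to the shared core. On these data alone, the contribution of the second stereo element also remains open.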